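Series notes: chain-end change on the chloro compound

The source may hold more compounds than are shown below. What is called first, only, known or untested is meant among the compounds shown, and "the series" means these compounds.

Compound 1 `CCCCNc1ccnc2cc(Cl)ccc12` gives 7420 nM in a functional assay on MDA-MB-468 cells (Homo sapiens) for cytotoxicity, read by sulforhodamine B assay, with a stated time of 48 h, in the presence of a further agent that is not named here; a lower number here means a stronger inhibitor of growth, a higher number a weaker inhibitor of growth. Of the two numbers in hand it is the higher; its nearest neighbour is compound 2 `CCCCNc1ccnc2cc(F)ccc12`, which gives 3500 nM in this assay, the step of a 2.1-fold lower number from compound 1 to compound 2 (0.33 log units; beyond the scatter) arising from fluoro in place of chloro on an aromatic carbon.

Compound 3 `CN(C)CCNc1ccnc2cc(Cl)ccc12` has not been measured in this assay. It differs from compound 1 by dimethylamino in place of ethyl on a saturated chain carbon, two bonds along the chain from a nitrogen on an aromatic ring, the chloro substituent being kept. For the measured compounds named here, no measured step touches this part of the structure: the only step available concerns the halogen on the aromatic carbon, and it is modest. Going by the values given here, the change in the chain therefore has no precedent here, and the expectation is that the step of a 1.3-fold lower number from compound 1 to compound 3 (0.13 log units; within the scatter) is estimated to fall within the usual scatter, in either direction, with the possibility of a larger move in either direction left open. Compound 3 is expected to give about 5500 nM in this assay, with a range from 1500 nM to 20000 nM.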

Compound 3, concentration for 50% growth inhibition: 19300 nM
Beside the measured number, compound 3's estimate is 3.5-fold (0.55 log units) below it; the range from low to high includes it.
By their numbers in this assay, from the lowest: compound 2; then compound 1; then compound 3.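

Series notes: the chain end on the chloro compound

In this assay, for the compounds shown here, the exchange of ethyl for dimethylamino on a saturated chain carbon, two bonds along the chain from a nitrogen on an aromatic ring, gives a 2.6-fold higher number from compound 1 to compound 3 (0.42 log units; beyond the scatter) as the first reading on this part of the structure, since the earlier pair spoke only to the halogen on the aromatic carbon. The direction runs against that of the halogen change, which gave a 2.1-fold lower number from compound 1 to compound 2 (0.33 log units; beyond the scatter) on the same butyl compound, so the number is now seen to respond to the chain end as well as to the halogen, and on the chloro compound this chain-end change weakens growth inhibition. No supporting measurement bears on this shift, so the data offer no account of it.

One change of this kind cannot separate the part played by the nitrogen from that of the two methyl groups it carries, and a primary amine, a hydroxyl or a diethylamino group at the chain end would be needed to tell these apart. Also open, going by these compounds, is whether a longer chain between the two nitrogens would move the number further, and whether 2-(dimethylamino)ethyl has the same effect on the fluoro compound as on the chloro compound.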